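Piperazine aryl swap on the shared core: thiazolyl variant

This account rests on a few compounds, and the source may have more. Where it says the series, first, only, none or still open, it means among the compounds named here.

Compound 1, `O=C(CN1CCN(c2ccc(F)cc2)CC1)Nc1nc2c(s1)CCCC2`, gives 77 nM in an assay on isolated protein for inhibition of long-chain fatty acid transport protein 1 (Homo sapiens), read by scintillation counting, with a stated time of 20 min; on this read-out higher numbers stand for weaker inhibition and lower numbers for stronger inhibition.
Compound 2, `O=C(CN1CCN(c2ccncc2)CC1)Nc1nc2c(s1)CCCC2`, reaches only a limit of this assay, > 1000 nM.
Compound 3, `O=C(CN1CCN(c2ccc(F)cc2)CC1)Nc1nc2c(o1)CCCC2`, gives 180 nM in this assay.

Compound 1 holds the lowest of the two numbers shown; compound 3 sits a step beyond the scatter above it, and the remaining value is a limit rather than a number. The compound still to be measured is compound 4, `O=C(CN1CCN(c2nccs2)CC1)Nc1nc2c(s1)CCCC2`; the change from compound 1 is 1,3-thiazol-2-yl in place of 4-fluorophenyl on an amine nitrogen in a ring.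

Going by the values given here, one measured step bears on this change: an at least 12-fold higher number from compound 1 to compound 2 (1.11 log units; beyond the scatter), a large loss that left that compound at the limit of > 1000 nM in this assay, at which 1 of the 3 values shown sits. Both that step and the present one replace the 4-fluorophenyl on the amine nitrogen in the ring with an aromatic ring carrying nitrogen, so a step in the same direction, a weakening, is expected. The data hold no case of a five-membered ring at this place, so the size of the step is uncertain, and the expected step is a 5.2-fold higher number from compound 1 to compound 4 (0.72 log units; beyond the scatter). Compound 4 is therefore estimated at 400 nM, in a range from 100 nM to 2000 nM, with a fair chance that this assay again returns only a limit.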

Compound 4, half-maximal inhibitory concentration: 520 nM
Compound 4: the middle estimate sits 1.3-fold (0.11 log units) below what was measured, and the stated range covers the measured number.
By their numbers in this assay, from the lowest: compound 1; then compound 3; then compound 4. At a limit, above all of these: compound 2.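

Replacing 4-fluorophenyl with 1,3-thiazol-2-yl on the amine nitrogen in a ring gives a 6.8-fold higher number from compound 1 to compound 4 (0.83 log units; beyond the scatter) in this assay and so shows that a five-membered aromatic ring with 2 hetero atoms also falls short of 4-fluorophenyl at this place. The step of an at least 1.9-fold lower number from compound 2 to compound 4 (0.28 log units; that floor lies within the scatter) rests on the limit of compound 2, so the pyridin-4-yl and 1,3-thiazol-2-yl groups cannot be put in order at this place. Both nitrogen-bearing aromatic rings, in compound 2 and compound 4, read weaker than the 4-fluorophenyl of compound 1, and no compound shown at this place goes against that, though compound 4 returns a number in this assay where compound 2 returns only a limit.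

From the compounds shown here alone, it remains open whether the loss follows the ring nitrogen or simply the removal of the 4-fluorophenyl, a question that plain phenyl or a chlorophenyl at this place would address. Also open, going by these compounds, are how a simple alkyl chain or a group carrying a carboxylic acid would read on this nitrogen, and whether 1,3-thiazol-2-yl would give a similar step on the core of compound 3.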